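Pyrazole enones: switching the aryl on the carbonyl carbon

This account rests on a few compounds, and the source may have more. Where it says the series, first, only, none or still open, it means among the compounds named here.

Three compounds of the shared core carry a different aryl group on the carbonyl carbon. Compound 1 `COc1cc(-c2cc(/C=C/C(=O)c3ccc(N)cc3)[nH]n2)cc(OC)c1OC` gives -59% in a functional assay on UACC-257 cells (Homo sapiens) for cytotoxicity, read by sulforhodamine B assay, with a stated time of 48 h, tested at 10 uM; on this read-out higher numbers stand for a weaker effect at the one concentration tested and lower numbers for a stronger effect. Compound 2 `COc1cc(-c2cc(/C=C/C(=O)c3ccc(Cl)c(Cl)c3)[nH]n2)cc(OC)c1OC` gives 66% there, and compound 3 `COc1ccc(C(=O)/C=C/c2cc(-c3cc(OC)c(OC)c(OC)c3)n[nH]2)cc1` gives -65%. Compound 3 holds the lowest of the three numbers; its nearest neighbour is compound 1, lying within the scatter, and the furthest is compound 2, which is beyond it.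

Compound 4 `COc1cc(-c2cc(/C=C/C(=O)c3ccc(F)c(F)c3)[nH]n2)cc(OC)c1OC` has not been measured. It differs from compound 3 by 3,4-difluorophenyl in place of 4-methoxyphenyl on a carbonyl carbon.

Within the data shown here, two steps bear on this: a number 131 percentage points lower from compound 2 to compound 3 (beyond the scatter), and a number 125 percentage points higher from compound 1 to compound 2 (beyond the scatter). Both show that placing a phenyl carrying two halogens at this carbonyl carbon goes with a far higher number than a phenyl carrying methoxy or amino. Fluorine is not chlorine, so the size is uncertain, but the direction is expected to be the same: a number 85 percentage points higher from compound 3 to compound 4 (beyond the scatter) is the expected step. Compound 4 is therefore estimated at 20%, with a range from -40% to 70%.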

Compound 4, a percentage reported as activity, at one concentration (the size of the read-out at that concentration, not a potency): -18%
For compound 4 the middle estimate is 38 percentage points above the measured one; the measured number falls inside the stated range.
By their numbers in this assay, from the lowest: compounds 3 and 1 (each within the scatter of the next); then compound 4; then compound 2.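

Replacing the 3,4-dichlorophenyl with the 3,4-difluorophenyl on the carbonyl carbon gives a number 84 percentage points lower from compound 2 to compound 4 (beyond the scatter) in this assay, so two halogens at this position do not by themselves set the number, and the identity of the halogen matters here. The 3,4-difluorophenyl also stays apart from the groups carrying methoxy and amino, with a number 47 percentage points higher from compound 3 to compound 4 (beyond the scatter) and with a number 41 percentage points higher from compound 1 to compound 4 (beyond the scatter), placing compound 4 between those two compounds and compound 2. No measurement at hand speaks to the origin of these steps.

Going by these compounds, whether the number follows the kind of halogen or the number of halogens remains open, and 4-fluorophenyl and 4-chlorophenyl would bear on this. A read-out at one concentration also tells only whether the effect of each of the four compounds is stronger or weaker at that concentration.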